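Butyl for ethyl on the aminoacetamide side chain

The source may hold more compounds than are shown below. What is called first, only, known or untested is meant among the compounds shown, and "the series" means these compounds.

Compound 1 `CCCCNC(=O)Nc1cccc2c1CN(C)CC2c1ccc(C)cc1`: > 100 mg/kg
Compound 2 `CCNCC(=O)Nc1cccc2c1CN(C)CC2c1ccc(C)cc1`: about 15 mg/kg

Going by the values given here, in a functional assay on the whole organism for inhibition of sodium-dependent dopamine transporter (Mus musculus) (on this read-out lower numbers stand for an effect already at smaller amounts and higher numbers for an effect only at larger amounts of compound), compound 2 gives about 15 mg/kg, the only actual number among the values shown. Compound 1 sits at the limit of > 100 mg/kg in this assay, at which 1 of the 2 values shown sits, which is a limit of the assay and not a number. Among the compounds with values here, the one measured step, an at least 6.6-fold lower number from compound 1 to compound 2 (0.82 log units; beyond the scatter), bears on the question. Compound 3 `CCCCNCC(=O)Nc1cccc2c1CN(C)CC2c1ccc(C)cc1` differs from compound 2 by ethyl in place of hydrogen on a saturated chain carbon, two bonds along the chain from an amine nitrogen, bringing back the butylamino chain of compound 1. Because the step of an at least 6.6-fold lower number from compound 1 to compound 2 (0.82 log units; beyond the scatter) went down when that chain left, compound 3 is expected to move back up by a 2.3-fold higher number from compound 2 to compound 3 (0.37 log units; beyond the scatter). The estimate for compound 3 is 35 mg/kg, from 12 mg/kg to 100 mg/kg.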

Compound 3, dose for half-maximal effect: 14 mg/kg
For compound 3 the middle estimate is 2.5-fold (0.40 log units) above the measured one; low and high end bracket the measured number.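

In this assay, the chain accepts ethyl at this place without a readable effect, with a 1.1-fold lower number from compound 2 to compound 3 (0.03 log units; within the scatter). The butylamino group alone therefore does not account for the poor result of compound 1, since keeping butylamino and changing only the link to the carbonyl carbon gives an at least 7.1-fold lower number from compound 1 to compound 3 (0.85 log units; beyond the scatter). The figure for compound 1 is a limit of the assay and not a number: the limit of > 100 mg/kg in this assay, at which 1 of the 3 values shown sits.

Going by these compounds, it remains open whether a longer chain such as hexyl on the amine nitrogen would hold this level, or whether a carboxylic acid at the chain end would.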